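This account rests on a few compounds, and the source may have more. Where it says the series, first, only, none or still open, it means among the compounds named here.

In a functional assay on MCF7 cells (Homo sapiens) for cytotoxicity, read by colorimetric assay and MTT assay (on this read-out higher numbers stand for weaker inhibition and lower numbers for stronger inhibition), compound 1 (`COc1ccc(-c2cc3c(OC)ccc(OC)c3nc2O)cc1`) gives 10000 nM, and compound 2 (`COc1cc(OC)c2cc(-c3ccc(OCc4ccccc4)cc3)c(O)nc2c1`) gives 10000 nM. Compound 3 (`CCOC(=O)Cn1c(=O)c(-c2ccc(OC)cc2)cc2c(OC)cc(OC)cc21`) stands level with both at 10000 nM. Compound 4 (`COc1ccc(-c2cc3c(OC)cc(OC)cc3n(CC(=O)O)c2=O)cc1`) has yet to be measured. It differs from compound 3 in one place: hydrogen in place of ethyl on an oxygen next to a carbonyl group. This puts hydrogen in place of ethyl on an oxygen next to a carbonyl group, turning ethoxycarbonyl into carboxy. For the measured compounds named here, no measured pair here shows what a single change does, so the closest guide is compound 3 at 10000 nM. The step expected in this assay is no change at the digits printed from compound 3 to compound 4 (within the scatter), none beyond the scatter and with no direction favoured. For compound 4 the estimated value is 10000 nM, with an expected range from 5000 nM to 20000 nM.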

Compound 4, half-maximal inhibitory concentration: 10000 nM
Compound 4: the middle estimate sits on the measured number at the digits printed, within the range that was stated.
By their numbers in this assay, from the lowest: compounds 1, 2, 3 and 4 (each within the scatter of the next).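

In this assay, for the compounds shown here, the swap of ethoxycarbonyl for carboxy gives no change at the digits printed from compound 3 to compound 4 (within the scatter) and is the first single change that can be read in this set. At this position, ethyl on an oxygen next to a carbonyl group can give way to hydrogen with no shift in the number. From the compounds shown here alone, whether an amine or a longer chain in place of carboxymethyl would move the value stays open, as does the effect of changes on the shared core. No measurement at hand offers a reason for this result.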